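A Ring Swap Three Bonds Along the Chain

A few compounds are considered here, and "the series" means these few. Any claim that something is new, unique, unknown or untested is made for them only; others in the source may bear on it.

Compound 1 `CCCCCNC(=O)Nc1c(OCCCn2cnc(-c3ccccc3)c2)cccc1N(C)C` carries a 4-phenyl-1H-imidazol-1-yl group on a saturated chain carbon, three bonds along the chain from an oxygen on an aromatic ring. For the measured compounds named here, in an assay on aorta for inhibition of acyl-CoA:cholesterol acyltransferase (Oryctolagus cuniculus) (on this read-out lower numbers stand for stronger inhibition and higher numbers for weaker inhibition), compound 1 gives 160 nM, the lowest of the two numbers so far. Its companion compound 2 `CCCCCN(C)C(=O)Nc1c(OCCCn2cnc(-c3ccccc3)c2)cccc1N(C)C` differs only by a methyl in place of hydrogen on an amide-type nitrogen and gives 280 nM; the step of a 1.8-fold higher number from compound 1 to compound 2 (0.24 log units; within the scatter) lies within the scatter. Compound 3 `CCCCCNC(=O)Nc1c(OCCCn2ncc(-c3ccccc3)n2)cccc1N(C)C` keeps that nitrogen untouched and instead alters the ring on the chain: a group of 11 heavy atoms (8 carbon, 3 nitrogen; one five-membered aromatic ring with 3 hetero atoms, one six-membered aromatic ring of carbon only) in place of a group of 11 heavy atoms (9 carbon, 2 nitrogen; one five-membered aromatic ring with 2 hetero atoms, one six-membered aromatic ring of carbon only), on a saturated chain carbon, three bonds along the chain from an oxygen on an aromatic ring. Going by the values given here, no measured step touches this part of the molecule, so the single known step offers no guide to the size or direction of the change. Compound 3 is therefore expected to show a step of a 1.6-fold higher number from compound 1 to compound 3 (0.19 log units; within the scatter), small and uncertain in direction. The estimate for compound 3 in this assay is 250 nM, within a range from 80 nM to 900 nM.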

Compound 3, half-maximal inhibitory concentration: 180 nM
The estimate for compound 3 lay 1.4-fold (0.14 log units) above the measured number; measured number inside the range.
By their numbers in this assay, from the lowest: compounds 1, 3 and 2 (each within the scatter of the next).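

Swapping the 4-phenyl-1H-imidazol-1-yl group for a group with one five-membered aromatic ring with 3 hetero atoms takes the count of hydrogen-bond acceptors from 2 to 3, and in this assay it gives a 1.1-fold higher number from compound 1 to compound 3 (0.05 log units; within the scatter). This place on the chain, three bonds along the chain from an oxygen on an aromatic ring, therefore accepts this exchange of a ring carbon for a nitrogen without a change that the read-out can separate from the scatter. No supporting measurement bears on why the two rings read alike.

As far as these compounds go, it remains open whether the same holds for a very different group here, such as a simple amine or a carboxylic acid in place of the ring. From the compounds shown here alone, a longer chain carrying either ring, or the new ring combined with the methyl on the amide-type nitrogen, is equally open.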